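The compounds below may be only part of what the source reports. "The series", "measured", "known", "first", "only" and "open" are said of these compounds alone.

Measured in an in vitro ADME assay on microsomes from liver (Homo sapiens) for metabolic stability, tested at 5 uM; on this read-out lower numbers stand for a shorter-lived compound and higher numbers for a longer-lived compound:
- Compound 1 `COCN(c1ccc2c(c1)S(=O)(=O)N=C(c1c(O)c(-c3cccs3)nn(CCC(C)C)c1=O)N2)S(C)(=O)=O`: 0.183 h
- Compound 2 `CC(C)CCn1nc(-c2cccs2)c(O)c(C2=NS(=O)(=O)c3cc(S(C)(=O)=O)ccc3N2)c1=O`: 0.0933 h
- Compound 3 `CC(C)CCn1nc(C2CCC2)c(O)c(C2=NS(=O)(=O)c3cc(NS(C)(=O)=O)ccc3N2)c1=O`: 0.317 h

Compound 3 stands level with compound 1 within the scatter, and its number lies beyond the scatter above that of compound 2. Compound 4 `CC(C)CCc1nn(CCC(C)C)c(=O)c(C2=NS(=O)(=O)c3cc(NS(C)(=O)=O)ccc3N2)c1O` departs from compound 3 by isopentyl in place of cyclobutyl on an aromatic carbon, with isopentyl in place of cyclobutyl on an aromatic carbon. Within the data shown here, the only measured step, a 2.0-fold lower number from compound 1 to compound 2 (0.29 log units; within the scatter), lies within the scatter and concerns a different group, so it offers no direct guide to this change. The expectation therefore stays close to compound 3 at 0.317 h in this assay. An estimated 1.4-fold lower number from compound 3 to compound 4 (0.16 log units; within the scatter) is expected, which would not go beyond the scatter. Compound 4 is expected at 0.22 h, with an estimated range from 0.1 h to 0.45 h.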

Compound 4, half-life: 0.167 h
Compound 4: the middle estimate sits 1.3-fold (0.12 log units) above what was measured, and the stated range covers the measured number.
By their numbers in this assay, from the lowest: compounds 2, 4, 1 and 3 (each within the scatter of the next, the first and the last beyond it).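

In this assay, isopentyl in place of cyclobutyl on this aromatic carbon, next to the ring nitrogen and ortho to a hydroxy group, gives a 1.9-fold lower number from compound 3 to compound 4 (0.28 log units; within the scatter). Among these compounds, this is the first reading at this position, and it shows that an open chain can replace the four-membered carbon ring without a step beyond the scatter. No evidence is available that accounts for this step. Going by these compounds, whether an amine or a carboxylic acid on this carbon would move the number beyond the scatter remains open.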